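1,3-Benzothiazol-2-yl in place of 1H-benzimidazol-2-yl on sulfur

The source may report more compounds than this note shows. Statements on the series, on what has been measured and on what is new or still open speak of the compounds shown alone.

In an ADME assay on HMEC cells (Homo sapiens) for cytotoxicity, read by MTT assay (a lower number here means a stronger inhibitor, a higher number a weaker inhibitor), compound 1 `Nc1ccccc1NC(=O)c1ccc(CSc2nc3ccc(NCc4ccccn4)cc3s2)cc1` gives 8000 nM and compound 2 `Nc1ccccc1NC(=O)c1ccc(CSc2nc3ccccc3[nH]2)cc1` gives 14000 nM as its reading. These two numbers lie within the scatter of each other, so compound 2 stands level with compound 1 on the data so far. Compound 3 `Nc1ccccc1NC(=O)c1ccc(CSc2nc3ccccc3s2)cc1` is still unmeasured. It carries 1,3-benzothiazol-2-yl in place of 1H-benzimidazol-2-yl on a sulfur and is otherwise the same as compound 2. Going by the values given here, no measured pair shows this change, so the expectation in this assay rests on little. The reference point is compound 2 at 14000 nM as measured. The expected move is a 1.4-fold lower number from compound 2 to compound 3 (0.15 log units; within the scatter) towards a slightly lower number and is not expected to exceed the scatter. The estimated value for compound 3 is 10000 nM with an expected range from 4000 nM to 25000 nM on repeat measurement.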

Compound 3, half-maximal inhibitory concentration: 3000 nM
The estimate for compound 3 lay 3.3-fold (0.52 log units) above the measured number; measured number below the stated range.
By their numbers in this assay, from the lowest: compound 3; then compounds 1 and 2 (each within the scatter of the next).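

In this assay the group on sulfur now shows a step beyond the scatter: 1,3-benzothiazol-2-yl in place of 1H-benzimidazol-2-yl gives a 4.7-fold lower number from compound 2 to compound 3 (0.67 log units; beyond the scatter) with the rest of the structure unchanged. With 1,3-benzothiazol-2-yl held constant, hydrogen in place of ((pyridin-2-yl)methyl)amino on an aromatic carbon gives a 2.7-fold lower number from compound 1 to compound 3 (0.43 log units; beyond the scatter) and leaves compound 3 with the lowest number of the three, so that substituent is not required for the reading in this assay. No measurement shown accounts for either step.

From the compounds shown here alone, whether the step on sulfur extends to other rings, such as 1,3-benzoxazol-2-yl, remains open. Also open, going by these compounds, is whether a plain amine or a carboxylic acid on that aromatic carbon would read like hydrogen or like ((pyridin-2-yl)methyl)amino.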